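Methyl for Fluoro on the Aromatic Ring of Compound 2

A few compounds are considered here, and "the series" means these few. Any claim that something is new, unique, unknown or untested is made for them only; others in the source may bear on it.

Measured so far:
compound 1 `CO[C@@]12CCN(C)C[C@H]1[C@H](c1ccc(Cl)cc1)C(C#N)=C(N)O2` — 10500 nM
compound 2 `CO[C@@]12CCN(C)C[C@H]1[C@H](c1ccc(F)cc1)C(C#N)=C(N)O2` — 19400 nM

In a functional assay on trachea (Cavia porcellus) (on this read-out higher numbers stand for weaker inhibition and lower numbers for stronger inhibition), compound 1 gives 10500 nM and compound 2 gives 19400 nM. Among the measured compounds shown here, the one step measured between them is a 1.8-fold higher number from compound 1 to compound 2 (0.27 log units; within the scatter), so the two compounds cannot be placed in order on this read-out. Compound 2 thus holds the highest of two numbers, with compound 1 the nearest and that gap within the scatter.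

Compound 3 `CO[C@@]12CCN(C)C[C@H]1[C@H](c1ccc(C)cc1)C(C#N)=C(N)O2` differs from compound 2 by methyl in place of fluoro on an aromatic carbon. For the measured compounds named here, the only step measured so far, from compound 1 to compound 2, exchanges one halogen for another at this position and is within the scatter; no measured step exchanges a halogen for a methyl group, so the data give no direct guide for this change. On that basis compound 3 is expected to show no step beyond the scatter in this assay, which means an expected change of a 1.3-fold lower number from compound 2 to compound 3 (0.11 log units; within the scatter). Compound 3 is accordingly estimated at 15000 nM, with a range from 5000 nM to 45000 nM.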

Compound 3, half-maximal inhibitory concentration: 13200 nM
Compound 3: the middle estimate sits 1.1-fold (0.06 log units) above what was measured; the range from low to high includes it.
By their numbers in this assay, from the lowest: compounds 1, 3 and 2 (each within the scatter of the next).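

Compound 3 places the first group other than a halogen on the aromatic carbon para to a large group. In this assay the change from 4-fluorophenyl to 4-methylphenyl gives a 1.5-fold lower number from compound 2 to compound 3 (0.17 log units; within the scatter) and the exchange of chloro for methyl gives a 1.3-fold higher number from compound 1 to compound 3 (0.10 log units; within the scatter) as well. Both steps lie within the scatter, so fluoro, chloro and methyl at this carbon cannot be placed in order on this read-out, something the earlier pair, which held only two halogens, could not show for a carbon group. Nothing measured here speaks to the reason for this result.

The compounds shown leave open whether a group of another kind at this carbon, such as an amine, a carboxylic acid or a longer chain, would produce a step beyond the scatter. They also leave open whether methyl or a halogen on another carbon of the aromatic ring would read the same way in this assay on the shared core.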